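The compounds below may be only part of what the source reports. "The series", "measured", "known", "first", "only" and "open" are said of these compounds alone.

Measured compounds in the series:

- compound 1 `COc1ccccc1/C=c1/[nH]c(=O)/c(=C\c2ccccc2OC)n(C)c1=O`: 2200 nM
- compound 2 `C=CCn1c(=O)/c(=C\c2ccccc2Cl)[nH]c(=O)/c1=C\c1ccccc1OC`: 2500 nM
- compound 3 `C=CCn1c(=O)/c(=C\c2ccc(Cl)c(Cl)c2)[nH]c(=O)/c1=C\c1ccccc1OC`: "not active" (no number reported), no number reported

In a functional assay on K562 cells (Homo sapiens) for cytotoxicity, read by CCK-8 assay, with a stated time of 72 h (on this read-out higher numbers stand for weaker inhibition and lower numbers for stronger inhibition), compound 1 gives 2200 nM and compound 2 gives 2500 nM; the two values lie within the scatter of each other. Compound 3 gives "not active" (no number reported) in this assay and has no single number, so it stands apart from compound 1 and compound 2 only in that no concentration was reported for it.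

The next compound, compound 4 `C=CCn1c(=O)/c(=C\c2cccc(Br)c2)[nH]c(=O)/c1=C\c1ccccc1OC`, differs from compound 3 in one place: 3-bromophenyl in place of 3,4-dichlorophenyl on a double-bonded chain carbon bound to an aromatic carbon. Within the data shown here, no measured pair shows the effect of this change, so the size of the step cannot be read from the numbers on hand. Given that compound 3 returned no number, and that compound 1 and compound 2 sit in the low micromolar region, compound 4 is expected to land somewhere between those outcomes, most likely weaker than compound 1 and compound 2, with a real chance that this assay again reports no number.

Compound 4 is estimated to give about 6000 nM in this assay, with a plausible range from 1500 nM to 25000 nM.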

Compound 4, half-maximal inhibitory concentration: 2400 nM
The estimate for compound 4 lay 2.5-fold (0.40 log units) above the measured number, and the stated range covers the measured number.
By their numbers in this assay, from the lowest: compounds 1, 4 and 2 (each within the scatter of the next).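

In this assay, the step from 2-chlorophenyl to 3-bromophenyl on a double-bonded chain carbon bound to an aromatic carbon is a 1.0-fold lower number from compound 2 to compound 4 (0.02 log units; within the scatter) and so does not separate these two groups at this place. Compound 3, with 3,4-dichlorophenyl at the same place, gives "not active" (no number reported) while compound 4 gives 2400 nM in this assay, which shows that a single halogen-bearing phenyl can keep a reported concentration where the dichlorinated group has none, though the size of this step cannot be read. Halogen-bearing phenyl groups therefore do not behave as one class here: compound 2 and compound 4 yield numbers, and compound 3 goes against any such pattern.

On these data alone, whether the missing number belongs to 3,4-dichlorophenyl alone remains open, as does the outcome for a phenyl group carrying an amine or a carboxylic acid in place of the halogens at this position. Nothing on hand accounts for the difference in outcome between compound 3 and compound 4.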